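The source may report more compounds than this note shows. Statements on the series, on what has been measured and on what is new or still open speak of the compounds shown alone.

Measured so far in an ADME assay on MDBK cells (Bos taurus) for cytotoxicity; on this read-out lower numbers stand for higher toxicity in this test and higher numbers for lower toxicity in this test:
compound 1 `COc1ccccc1Cn1ccc2nc(-c3ccccc3)nc-2c1` gives > 100000 nM, a limit of the test.
compound 2 `COc1cccc(Cn2ccc3nc(-c4ccccc4)nc-3c2)c1` gives > 100000 nM, also a limit of the test.
compound 3 `c1ccc(-c2ccc(Cn3ccc4nc(-c5ccccc5)nc-4c3)cc2)cc1` gives 18000 nM.

Compound 1 thus stands at a limit of this assay; no number is known for it, only a limit. Among the measured compounds shown here, the single measured step that starts from compound 1 is a step that the two limits leave unreadable from compound 1 to compound 2, and its size cannot be read because both of its ends sit at the limit of > 100000 nM in this assay, at which 2 of the 3 values shown sit. For the measured compounds named here, compound 3 is the one compound of the set with an actual number, and its value shows measurable toxicity in this assay.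

Compound 4 `CCn1ccc2nc(-c3ccccc3)nc-2c1` has not yet been measured. It differs from compound 1 in one place: methyl in place of 2-methoxyphenyl on a saturated chain carbon bound to an aromatic nitrogen. No measured step involves a methyl on this carbon, so nothing shown gives the size of the step directly; the expectation rests on the fact that compound 1 and compound 2, which both carry a methoxyphenyl there, sit at the limit of > 100000 nM in this assay, at which 2 of the 3 values shown sit. The estimate for compound 4 is therefore 150000 nM, with a range from 50000 nM to 500000 nM, most likely again reported only as a limit. The expected step that the limit leaves unreadable from compound 1 to compound 4 is none beyond the scatter.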

Compound 4, half-maximal cytotoxic concentration: > 100000 nM
Compound 4 was reported as a limit; the forecaster's own chance of this, stated with the estimate: 70%; the middle value does not contradict the limit.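

In this assay, compound 4 sits at a limit of the test, as do compound 1 and compound 2, so no step among these three compounds can be read: the limit of > 100000 nM in this assay, at which 3 of the 4 values shown sit. The compounds shown leave open whether methyl and the two methoxyphenyl groups differ at all in this test; none of the three has an actual number.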